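A few compounds are considered here, and "the series" means these few. Any claim that something is new, unique, unknown or untested is made for them only; others in the source may bear on it.

Compound 1 `COc1ccc(NC(=O)c2nc(-c3cc(OC)c(OC)c(OC)c3)n(-c3ccc(OC)cc3)n2)cc1` gives 51% in a functional assay on the whole organism for inhibition, with Rattus norvegicus as the target, read by paw edema, with stated times of 30 min and 5 h, at a dose of 0.28 mmol/kg by the oral route (a lower number here means less inhibition, a higher number more inhibition at the dose given (going by the name of the read-out)), and compound 2 `COc1ccc(-n2nc(C(=O)Nc3ccccc3C)nc2-c2cc(OC)c(OC)c(OC)c2)cc1` gives 47%. The only measured step, a number 4 percentage points lower from compound 1 to compound 2 (within the scatter), stays within the scatter, so on the numbers shown compound 2 holds the lower of the two values without being separable from compound 1. Compound 3 `COc1ccc(-n2nc(C(=O)Nc3ccc(C(F)(F)F)cc3)nc2-c2cc(OC)c(OC)c(OC)c2)cc1` carries the change (4-(trifluoromethyl)phenyl in place of 2-methylphenyl on an amide-type nitrogen). Among the compounds with values here, no measured step covers this exact exchange; the one step on the same amide-type nitrogen was within the scatter, so the expected step is no change at the digits printed from compound 2 to compound 3 (within the scatter), none beyond the scatter. Compound 3 is therefore estimated at 47%, with a range from 30% to 62%.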

Compound 3, a percentage reported as inhibition, in the whole organism at one dose (the size of the read-out at that dose, not a potency): 50%
Estimate against measurement, compound 3: 3 percentage points below; measured number inside the range.
By their numbers in this assay, from the lowest: compounds 2, 3 and 1 (each within the scatter of the next).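

On the amide-type nitrogen, the exchange of 2-methylphenyl for 4-(trifluoromethyl)phenyl gives a number 3 percentage points higher from compound 2 to compound 3 (within the scatter) in this assay and so does not separate these two groups. Trifluoromethyl in place of methoxy on an aromatic carbon gives a number 1 percentage points lower from compound 1 to compound 3 (within the scatter) as well, so no step among the three groups on this nitrogen lies beyond the scatter. Nothing available explains these values.

Still open, on these data alone, is whether a carboxylic acid or an amine on that phenyl ring, or a longer alkyl chain in place of the ring, would give a step beyond the scatter.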